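Cytotoxicity series: para substituent on the phenyl ring

This account rests on a few compounds, and the source may have more. Where it says the series, first, only, none or still open, it means among the compounds named here.

Measured compounds:
compound 1 `Cn1nnnc1SCC(=O)N/N=c1/scc(-c2ccc(Br)cc2)n1-c1ccccc1` — 19.3 ug/mL
compound 2 `COc1ccc(-c2cs/c(=N/NC(=O)CSc3nnnn3C)n2-c2ccccc2)cc1` — 45 ug/mL
compound 3 `Cn1nnnc1SCC(=O)N/N=c1/scc(-c2ccc(C#N)cc2)n1-c1ccccc1` — 213 ug/mL

All three share one core and differ only in the group on the pendant phenyl ring. In an ADME assay on NIH3T3 cells (Mus musculus) for cytotoxicity, read by MTT assay, with a stated time of 24 h (a higher number here means a weaker inhibitor, a lower number a stronger inhibitor), compound 3 gives the highest number of the three: an 11-fold higher number from compound 1 to compound 3 (1.04 log units; beyond the scatter) and a 4.7-fold higher number from compound 2 to compound 3 (0.68 log units; beyond the scatter) both run upward to it, and the smaller step of a 2.3-fold higher number from compound 1 to compound 2 (0.37 log units; beyond the scatter) sits between the other two compounds.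

Compound 4 `Cn1nnnc1SCC(=O)N/N=c1/scc(-c2ccc(Cl)cc2)n1-c1ccccc1` has not yet been measured. The change from compound 3 is chloro in place of cyano on an aromatic carbon. The step that bears most directly on it is the one from bromo to cyano, an 11-fold higher number from compound 1 to compound 3 (1.04 log units; beyond the scatter), read in reverse: replacing cyano with another single-atom halogen substituent is expected to undo much of that rise. The step of a 4.7-fold higher number from compound 2 to compound 3 (0.68 log units; beyond the scatter) points the same way. A large downward step is therefore expected, an 8.5-fold lower number from compound 3 to compound 4 (0.93 log units; beyond the scatter), landing compound 4 close to compound 1 rather than compound 2. Compound 4 is expected to give about 25 ug/mL in this assay, within 10 ug/mL to 70 ug/mL.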

Compound 4, half-maximal inhibitory concentration: 40 ug/mL
The estimate for compound 4 lay 1.6-fold (0.20 log units) below the measured number; the range from low to high includes it.
By their numbers in this assay, from the lowest: compound 1; then compounds 4 and 2 (each within the scatter of the next); then compound 3.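

In this assay, swapping the nitrile for chloro recovers most of the rise seen with cyano, a 5.3-fold lower number from compound 3 to compound 4 (0.73 log units; beyond the scatter), so the high number of compound 3 is not shared by either halogen compound in the set. The two halogens still do not behave as equivalents, with a 2.1-fold higher number from compound 1 to compound 4 (0.32 log units; beyond the scatter), while a 1.1-fold lower number from compound 2 to compound 4 (0.05 log units; within the scatter) leaves chloro and methoxy indistinguishable at this position, although the step between bromo and methoxy lies beyond the scatter. No evidence is available to explain these differences.

Open, on these data alone, is whether fluoro, an amine or a carboxylic acid at this position would stay with compounds 1, 2 and 4 or move towards compound 3. Also open, as far as these compounds go, is whether these steps carry over when another part of the shared core changes.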